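The source may hold more compounds than are shown below. What is called first, only, known or untested is meant among the compounds shown, and "the series" means these compounds.

Of the compounds shown here, two sharing one core have been measured in an ADME assay on PC-3 cells (Homo sapiens) for cytotoxicity, read by WST assay, tested at 100 uM; on this read-out higher numbers stand for more inhibition at the one concentration tested (going by the name of the read-out) and lower numbers for less inhibition. Compound 1, `Cc1cccc(C(=O)N2CCCC(C(=O)Nc3ccc(Cl)cc3)C2)c1`, gives 0% in this assay, the lowest of the two numbers recorded. Compound 2, `O=C(Nc1ccc(Cl)nc1)C1CCCN(C(=O)c2cc(C(F)(F)F)cc(C(F)(F)F)c2)C1`, gives 25% in this assay, a number that lies beyond the usual scatter above the value of compound 1.

Compound 3, `CCN(CC)S(=O)(=O)c1cccc(C(=O)N2CCCC(C(=O)Nc3ccc(Cl)cc3)C2)c1`, has not yet been measured. It differs from compound 1 in one place: diethylsulfamoyl in place of methyl on an aromatic carbon. Among the compounds with values here, no measured pair shows what such a change does here, so the expectation rests on compound 1 alone. The step from compound 1 to compound 3 in this assay is expected to be small, a number 10 percentage points higher from compound 1 to compound 3 (within the scatter), toward more inhibition if anything, and it may well stay within the scatter. Compound 3 is therefore expected to give about 10% in this assay, within a range from 0% to 30%.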

Compound 3, a percentage reported as inhibition, at one concentration (the size of the read-out at that concentration, not a potency): 0%
Beside the measured number, compound 3's estimate is 10 percentage points above it; measured number inside the range.
By their numbers in this assay, from the lowest: compounds 1 and 3 (each within the scatter of the next); then compound 2.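

Putting diethylsulfamoyl in place of methyl on this aromatic carbon gives no change at the digits printed from compound 1 to compound 3 (within the scatter) in this assay. At this position, then, a group of 8 heavy atoms carrying hydrogen-bond acceptors gives the same printed number as a single methyl carbon, and compound 3 shows no inhibition at the one concentration tested. No information at hand explains this result.

On these data alone, whether an amine or a carboxylic acid at this position, or a longer alkyl chain, would give a number beyond the scatter remains open. Also open, as far as these compounds go, is whether diethylsulfamoyl would behave the same way on a compound that already shows some inhibition in this assay, as the present pair starts from a methyl compound showing none.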